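Swapping Phenyl for Chloropyridinyl on a Shared Core

A few compounds are considered here, and "the series" means these few. Any claim that something is new, unique, unknown or untested is made for them only; others in the source may bear on it.

Two compounds with a shared five-membered core carrying a carboxymethyl group have been measured in an in vitro assay on HEK385-7 cells for displacement of a labelled ligand from prostaglandin D2 receptor 2 (Homo sapiens); a higher number here means a weaker inhibitor, a lower number a stronger inhibitor. Compound 1 `O=C(O)Cc1sc(C(c2ccc(F)cc2)c2ccc(F)cc2)nc1-c1ccccc1` gives 16 nM in this assay, and compound 2 `O=C(O)Cc1sc(C(c2ccccc2)c2ccccc2)nc1-c1cccc(F)c1` gives 2.9 nM. Of the two numbers, compound 1 stands at the higher one, with compound 2 lower by a gap that lies beyond the usual scatter. No direct comparison between these two compounds is described, so the pair says only that much.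

Compound 3 `O=C(O)Cc1sc(C(c2ccc(F)cc2)c2ccc(F)cc2)nc1-c1ccnc(Cl)c1` is not yet measured. It differs from compound 1 in one place: 2-chloropyridin-4-yl in place of phenyl on an aromatic carbon. Among the measured compounds shown here, nothing among the measured compounds shows what such a swap does, so the expectation rests on the observation that both measured compounds fall in a fairly narrow band of this assay. The step from compound 1 to compound 3 is expected to be small, most likely within the scatter, with no direction favoured: a 1.3-fold higher number from compound 1 to compound 3 (0.10 log units; within the scatter). Compound 3 is therefore estimated at 20 nM in this assay, within a range from 6 nM to 65 nM.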

Compound 3, half-maximal inhibitory concentration: 3.1 nM
Beside the measured number, compound 3's estimate is 6.5-fold (0.81 log units) above it; the whole stated range lies above it.
By their numbers in this assay, from the lowest: compounds 2 and 3 (each within the scatter of the next); then compound 1.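

In this assay, among the compounds shown here, putting 2-chloropyridin-4-yl in place of phenyl on the aromatic carbon next to the ring nitrogen gives a 5.2-fold lower number from compound 1 to compound 3 (0.71 log units; beyond the scatter), which is the first direct reading of this position. The step lies beyond the usual scatter, so what this position carries does matter for the measured number, and the change here leads to a stronger inhibitor. For the compounds shown here, the entering ring holds a ring nitrogen and a chlorine, and it counts a hydrogen-bond acceptor where phenyl has none, yet nothing measured so far explains why the number falls.

The swap changes the nitrogen and the chlorine together, so the compounds shown cannot say how much of the step belongs to each: a pyridinyl group without the chlorine and a chlorophenyl group without the ring nitrogen would separate the two. On these data alone, it also remains open whether another group in the place of the chlorine, such as a methyl or an amine, would give a similar number, and whether this swap would have the same effect on a different set of groups around the shared core.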